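Compound 3 and the group entering compound 4

This account rests on a few compounds, and the source may have more. Where it says the series, first, only, none or still open, it means among the compounds named here.

Three compounds share one core and differ in a single group on an aromatic carbon: compound 1 (`CC(=O)N[C@@H]1CCC[C@H](C(=O)Nc2cc(-c3cnc4n3CCCC4)c(Cl)cn2)C1`), compound 2 (`CC(=O)N[C@@H]1CCC[C@H](C(=O)Nc2cc(-c3cnc(C)n3C)c(Cl)cn2)C1`) and compound 3 (`CC(=O)N[C@@H]1CCC[C@H](C(=O)Nc2cc(-c3cnn4c3CCC4)c(Cl)cn2)C1`). In a physicochemical assay for solubility, in phosphate buffer, at pH 7.4 (a lower number here means a less soluble compound, a higher number a more soluble compound), compound 1 gives 600000 nM and compound 3 gives 160000 nM. Compound 2 gives > 1000000 nM, which is a limit of the assay and not a number. Compound 3 therefore holds the lower of the two actual numbers.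

Compound 4 (`CC(=O)N[C@@H]1CCC[C@H](C(=O)Nc2cc(-c3cnn4c3CN(C)CC4)c(Cl)cn2)C1`) changes the same place: a group of 10 heavy atoms (7 carbon, 3 nitrogen; one five-membered aromatic ring with 2 hetero atoms, one six-membered non-aromatic ring with 2 hetero atoms) in place of a group of 8 heavy atoms (6 carbon, 2 nitrogen; one five-membered non-aromatic ring with 1 hetero atom, one five-membered aromatic ring with 2 hetero atoms), on an aromatic carbon. The place is opposite the ring nitrogen and ortho to a chloro group. Among the measured compounds shown here, two measured steps bear on this change, and both are beyond the scatter: a 3.8-fold lower number from compound 1 to compound 3 (0.57 log units; beyond the scatter) and an at least 6.2-fold lower number from compound 2 to compound 3 (0.79 log units; beyond the scatter). Both end on compound 3, so the group in compound 3 gave the lower number in each comparison. The group in compound 4 has a six-membered non-aromatic ring, as does the group in compound 1 at 600000 nM, although with 2 hetero atoms rather than 1. A move up towards that value is therefore expected in this assay. The expected step is a 2.8-fold higher number from compound 3 to compound 4 (0.45 log units; beyond the scatter), of modest size and towards a higher number. For compound 4 the estimated value is 450000 nM, with an expected range of 170000 nM to 1000000 nM.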

Compound 4, solubility: 870000 nM
For compound 4 the middle estimate is 1.9-fold (0.29 log units) below the measured one, and the stated range covers the measured number.
By their numbers in this assay, from the lowest: compound 3; then compounds 1 and 4 (each within the scatter of the next). At a limit, above all of these: compound 2.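

In this assay, the group with a six-membered non-aromatic ring with 2 hetero atoms replaces the group of compound 3 with a step beyond the scatter, a 5.4-fold higher number from compound 3 to compound 4 (0.74 log units; beyond the scatter), so compound 3 now stands lowest against two other groups with numbers. The two groups with a six-membered non-aromatic ring are not separated (a 1.5-fold higher number from compound 1 to compound 4 (0.16 log units; within the scatter)), so the second hetero atom in the six-membered non-aromatic ring shows no readable change in this comparison. The group with a five-membered non-aromatic ring stands beyond the scatter from both of them (the second step: a 3.8-fold lower number from compound 1 to compound 3 (0.57 log units; beyond the scatter)), a pattern that rests on these three compounds alone. Compound 2 carries a limit of the assay and not a number: the limit of > 1000000 nM in this assay, at which 1 of the 4 values shown sits.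

Its step is known only as a floor (an at least 1.1-fold lower number from compound 2 to compound 4 (0.06 log units; that floor lies within the scatter)), so it gives no order between the two compounds.

The compounds shown do not separate ring size from hetero atom count, and a six-membered non-aromatic ring with an oxygen as its second hetero atom, or a five-membered non-aromatic ring holding an amine, would bear on that. On these data alone, how these groups behave in any other read-out also stays open.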